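The source may hold more compounds than are shown below. What is called first, only, known or untested is meant among the compounds shown, and "the series" means these compounds.

Measured so far:
Compound 1 `COc1cc2c(cc1OC)C(CC(=O)N1CCCC1)CC2`: 26.1%
Compound 2 `COc1cc2c(cc1OC)C(CC(=O)N1CCCCC1)CC2`: 31.9%

In a functional assay on the whole organism (strain Wistar) for inhibition, with Rattus norvegicus as the target, read by paw edema, with stated times of 60 min and 3 h, at a dose of 100 mg/kg by the oral route (on this read-out lower numbers stand for less inhibition and higher numbers for more inhibition at the one dose given (going by the name of the read-out)), compound 2 stands highest of the two numbers shown, though the only measured step, a number 5.8 percentage points higher from compound 1 to compound 2 (within the scatter), lies within the scatter, so the two values cannot be told apart. Compound 3 `COc1cc2c(cc1OC)C(CC(=O)N1CCNCC1)CC2` differs from compound 2 by piperazin-1-yl in place of piperidin-1-yl on a carbonyl carbon. Among the compounds with values here, the one known step swapped ring sizes rather than adding a ring nitrogen, so it bears only loosely on this change; it suggests that altering the amine ring moves the number little, and the expected step is none beyond the scatter, a number 3.9 percentage points lower from compound 2 to compound 3 (within the scatter). Compound 3 is therefore estimated at 28%, in a range from 14% to 42%.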

Compound 3, a percentage reported as inhibition, in the whole organism at one dose (the size of the read-out at that dose, not a potency): 42%
Beside the measured number, compound 3's estimate is 14 percentage points below it, within the range that was stated.
By their numbers in this assay, from the lowest: compounds 1 and 2 (each within the scatter of the next); then compound 3.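

In this assay, the choice of amine ring on a carbonyl carbon now shows an effect beyond the scatter: piperazin-1-yl in place of piperidin-1-yl gives a number 10.1 percentage points higher from compound 2 to compound 3 (beyond the scatter), and piperazin-1-yl in place of pyrrolidin-1-yl gives a number 15.9 percentage points higher from compound 1 to compound 3 (beyond the scatter). Adding a ring nitrogen thus goes with a modest rise, whereas the change in ring size alone stayed within the scatter. Nothing available explains this rise.

Still open, as far as these compounds go, is whether the ring nitrogen's hydrogen matters. A 4-methylpiperazin-1-yl or morpholin-4-yl group at this position would address that question.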